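Series notes: arylhydrazine tail variation and cytotoxicity

A few compounds are considered here, and "the series" means these few. Any claim that something is new, unique, unknown or untested is made for them only; others in the source may bear on it.

The parent of the set is compound 1 `NNCc1cc(O)n2nc(N)c([N+](=O)[O-])c2n1`, which in an ADME assay (Homo sapiens) for cytotoxicity (on this read-out higher numbers stand for lower toxicity in this test and lower numbers for higher toxicity in this test), gives 42.6 ug/mL. Compound 2 `Nc1nn2c(O)cc(CNNc3ccc(F)cc3)nc2c1[N+](=O)[O-]` carries a 4-fluorophenyl on the amine nitrogen; in this assay compound 2 reaches only the limit of > 100 ug/mL, which is a limit and not a number. Compound 3 `COc1ccc(NNCc2cc(O)n3nc(N)c([N+](=O)[O-])c3n2)cc1` carries a 4-methoxyphenyl at the same position and in this assay compound 3 gives 66.3 ug/mL, the highest of the two numbers shown, though its nearest neighbour compound 1 lies within the scatter, as a 1.6-fold higher number from compound 1 to compound 3 (0.19 log units; within the scatter). The fluoro analogue gave an at least 2.3-fold higher number from compound 1 to compound 2 (0.37 log units; beyond the scatter). Between the two aryl tails the swap of the ring substituent gave an at least 1.5-fold lower number from compound 2 to compound 3 (0.17 log units; that floor lies within the scatter), so the numbers do not separate cleanly; one value of the set sits at the limit of > 100 ug/mL in this assay, at which 1 of the 3 values shown sits.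

Compound 4 `Nc1nn2c(O)cc(CNNc3ccc(S(=O)(=O)O)cc3)nc2c1[N+](=O)[O-]` is the next member: sulfo in place of methoxy on an aromatic carbon. Among the measured compounds shown here, no measured step covers a sulfo group. For the measured compounds named here, the only step that bears on a change of the ring substituent is an at least 1.5-fold lower number from compound 2 to compound 3 (0.17 log units; that floor lies within the scatter), which stayed within the scatter, so for compound 4 in this assay no step beyond the scatter is expected, with a slight lean toward a higher number given the limit of compound 2. Compound 4 is therefore estimated at 85 ug/mL, with a range from 45 ug/mL to 160 ug/mL, which means an expected step of a 1.3-fold higher number from compound 3 to compound 4 (0.11 log units; within the scatter).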

Compound 4, half-maximal cytotoxic concentration: > 50 ug/mL
Compound 4 gave a limit, no number; the forecaster's own chance of this, stated with the estimate: 35%; the middle value lies beyond the limit too.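

In this assay compound 4 gives > 50 ug/mL, which is a limit and not a number. Its steps from compound 3 and from compound 2 cannot be read. The compounds shown leave open how compound 4 compares with compound 2 and compound 3, and so how sulfo compares with methoxy or fluoro on the aromatic ring.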